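Chain extension in a cytotoxicity series

The source may hold more compounds than are shown below. What is called first, only, known or untested is meant among the compounds shown, and "the series" means these compounds.

Three compounds were tested in a functional assay on A549 cells (Homo sapiens) for cytotoxicity, read by MTT assay, with a stated time of 24 h, tested at 10 uM; a lower number here means a stronger effect, a higher number a weaker effect of the compound at the concentration tested. Compound 1 `CCCCCCCOC(=O)CCC(=O)N1CCN(CCCOc2cc3c(Nc4ccc(F)c(Cl)c4)ncnc3cc2OC)CC1` gives 89.1%, compound 2 `CCCCCCCCOC(=O)CCC(=O)N1CCN(CCCOc2cc3c(Nc4ccc(F)c(Cl)c4)ncnc3cc2OC)CC1` gives 87.3%, and compound 3 `CCCCCCCCCCOC(=O)CCC(=O)N1CCN(CCCOc2cc3c(Nc4ccc(F)c(Cl)c4)ncnc3cc2OC)CC1` gives 95.7%. Compound 3 has the highest of the three numbers; its nearest neighbour is compound 1 and its furthest is compound 2, and both gaps are within the scatter. The steps among the measured compounds are a number 1.8 percentage points lower from compound 1 to compound 2 (within the scatter), a number 6.6 percentage points higher from compound 1 to compound 3 (within the scatter) and a number 8.4 percentage points higher from compound 2 to compound 3 (within the scatter), none of them beyond the scatter.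

Compound 4 `CCCCCCCCCCCOC(=O)CCC(=O)N1CCN(CCCOc2cc3c(Nc4ccc(F)c(Cl)c4)ncnc3cc2OC)CC1` differs from compound 3 by methyl in place of hydrogen on a saturated chain carbon, ten or more bonds along the chain from an oxygen next to a carbonyl group. Each of the measured steps is a lengthening of the same chain, and each stayed within the scatter, so the change to compound 4 is expected to give no step beyond the scatter in this assay, estimated as a number 3.7 percentage points lower from compound 3 to compound 4 (within the scatter). Compound 4 is therefore estimated to give 92% in this assay, with an expected range from 84% to 100%.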

Compound 4, a percentage reported as activity, at one concentration (the size of the read-out at that concentration, not a potency): 93.4%
Beside the measured number, compound 4's estimate is 1.4 percentage points below it; the range from low to high includes it.
By their numbers in this assay, from the lowest: compounds 2, 1, 4 and 3 (each within the scatter of the next).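

In this assay, the methyl added on a saturated chain carbon gives a number 2.3 percentage points lower from compound 3 to compound 4 (within the scatter), while the larger extensions give a number 6.1 percentage points higher from compound 2 to compound 4 (within the scatter) and a number 4.3 percentage points higher from compound 1 to compound 4 (within the scatter), so all three steps to compound 4 remain small, and the chain series now spans four compounds without a step beyond the scatter. The methyl change now appears on a second pair, and its two steps agree: the same change on two cores in this assay, a number 1.8 percentage points lower (within the scatter) from compound 1 to compound 2 and a number 2.3 percentage points lower (within the scatter) from compound 3 to compound 4, 0.5 percentage points apart, within the scatter of two such steps. The larger chain change also appears on two pairs, and those steps agree too: the same change on two cores in this assay, a number 6.6 percentage points higher (within the scatter) from compound 1 to compound 3 and a number 6.1 percentage points higher (within the scatter) from compound 2 to compound 4, 0.5 percentage points apart, within the scatter of two such steps.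

These compounds leave open whether an amine or a carboxylic acid in place of the chain would give a step beyond the scatter. They also leave open whether a much longer chain or a much shorter one, such as methyl, would do so.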